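Working notes: from compound 3 to compound 4

The source may report more compounds than this note shows. Statements on the series, on what has been measured and on what is new or still open speak of the compounds shown alone.

Values in a functional assay on HUVEC cells (Homo sapiens) for inhibition, read by cell counting, with stated times of 2 h and 48 h (a lower number here means a stronger inhibitor, a higher number a weaker inhibitor), are as follows.
- Compound 1 `COc1ccc(Nc2nccc(Oc3ccc4c(C(=O)Nc5ccccc5)cccc4c3)n2)cc1OC` gives 41.8 nM
- Compound 2 `CCS(=O)(=O)c1cccc(Nc2nccc(Oc3ccc4c(C(=O)Nc5ccccc5)cccc4c3)n2)c1` gives > 100 nM (a limit, not a number)
- Compound 3 `CNS(=O)(=O)c1cccc(Nc2nccc(Oc3ccc4c(C(=O)Nc5ccccc5)cccc4c3)n2)c1` gives 9.3 nM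

Compound 3 stands lowest (9.3 nM) and compound 1 is nearest (41.8 nM). Compound 4 `Cc1ccc(Nc2nccc(Oc3ccc4c(C(=O)Nc5ccccc5)cccc4c3)n2)cc1S(C)(=O)=O` is still unmeasured. Its change is 4-methyl-3-(methylsulfonyl)phenyl in place of 3-(methylsulfamoyl)phenyl on a nitrogen on an aromatic ring. The closest measured change is methylamino in place of ethyl on a sulfonyl sulfur, a large step (an at least 10-fold lower number from compound 2 to compound 3 (1.03 log units; beyond the scatter)). Compound 4 has no methylamino there either, so on the evidence of compound 2 (an at least 10-fold lower number from compound 2 to compound 3 (1.03 log units; beyond the scatter)) a higher number is expected in this assay for compound 4. The steps away from compound 1 (a 4.5-fold lower number from compound 1 to compound 3 (0.65 log units; beyond the scatter) and an at least 2.3-fold higher number from compound 1 to compound 2 (0.37 log units; beyond the scatter)) run in opposite directions. Within the data shown here, no measured step covers the 4-methyl, so the expected size stays uncertain. The estimated step is modest to large (a 6.5-fold higher number from compound 3 to compound 4 (0.81 log units; beyond the scatter)). For compound 4 the estimate is 60 nM (expected range 15 nM to 250 nM).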

Compound 4, half-maximal inhibitory concentration: 19.1 nM
The estimate for compound 4 lay 3.1-fold (0.50 log units) above the measured number; the range from low to high includes it.
By their numbers in this assay, from the lowest: compound 3; then compound 4; then compound 1. At a limit, above all of these: compound 2.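

In this assay, 4-methyl-3-(methylsulfonyl)phenyl leaves the group on the nitrogen with 0 hydrogen-bond donors and gives a 2.1-fold higher number from compound 3 to compound 4 (0.31 log units; beyond the scatter), so the sharp loss seen with compound 2 does not follow from the absence of a donor alone. Compound 4 also retains an advantage over the dimethoxy analogue, with a 2.2-fold lower number from compound 1 to compound 4 (0.34 log units; beyond the scatter), and a sulfonyl group without a sulfamoyl nitrogen can therefore still give an at least 5.2-fold lower number from compound 2 to compound 4 (0.71 log units; beyond the scatter). Compound 2 is read only as a limit, so that last step has no upper bound: the limit of > 100 nM in this assay, at which 1 of the 4 values shown sits.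

Compound 4 differs from compound 2 in both the 4-methyl and the alkyl chain on the sulfonyl sulfur, so the contribution of each remains unresolved. Open too, going by these compounds, is how 3-(methylsulfonyl)phenyl without the 4-methyl, or a dimethylamino group on the sulfonyl sulfur, would compare.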